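Biaryl substituent swap on a nitrile-bearing core

The source may report more compounds than this note shows. Statements on the series, on what has been measured and on what is new or still open speak of the compounds shown alone.

The account follows two measured compounds and one that awaits measurement. For the measured compounds named here, compound 1, `CC[C@@H](Nc1c(C#N)c(-c2ccc(-c3cccc(C)c3)cc2)nc2cnccc12)C(N)=O`, is the more lipophilic of the two measured members: in a physicochemical assay for lipophilicity, read by HPLC, at pH 7.5 (on this read-out lower numbers stand for lower lipophilicity and higher numbers for higher lipophilicity), compound 1 gives 3. Compound 2, `CC(C)(CC(N)=O)c1c(C#N)c(-c2ccc(Br)cc2)nc2cnccc12`, shares the nitrile-bearing core but carries a different aryl group and a different side chain; in this assay compound 2 gives 2.1, which stands below the value of compound 1 by more than the usual scatter. The two compounds differ in several places at once, so no single structural step can be read from that gap.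

Compound 3, `CC[C@@H](Nc1c(C#N)c(-c2ccc(-c3ccccc3NC)cc2)nc2cnccc12)C(N)=O`, is derived from compound 1 by one change on an aromatic carbon: 2-(methylamino)phenyl in place of 3-methylphenyl on an aromatic carbon. The group that enters brings one hydrogen-bond donor and one hydrogen-bond acceptor where the group that leaves brought none, and it is one heavy atom larger.

For compound 3 the author expects a modest downward step a number 0.40 log units lower from compound 1 to compound 3 (beyond the scatter) in this assay, somewhat larger than the scatter. Compound 3 is accordingly estimated at 2.6, with a range from 2 to 3.2.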

Compound 3, distribution coefficient: 2.5
The estimate for compound 3 lay 0.10 log units above the measured number, and the stated range covers the measured number.
By their numbers in this assay, from the lowest: compound 2; then compound 3; then compound 1.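

The first two compounds differ in several places at once, so they could not show how this position behaves on its own. With 2-(methylamino)phenyl in place of 3-methylphenyl on an aromatic carbon, para to a large group, the read-out gives a number 0.50 log units lower from compound 1 to compound 3 (beyond the scatter) in this assay, which shows that this position responds to the change with a modest step beyond the scatter. The entering group is the larger of the two and brings a nitrogen, a hydrogen-bond donor and a hydrogen-bond acceptor, and it also differs from the leaving group in where its substituent stands, so this single step cannot assign the drop to any one of these differences, and nothing measured here accounts for it.

The compounds shown leave open how this read-out would answer if a hydroxyl, a methoxy or a carboxylic acid stood on that phenyl ring in place of the methylamino group. They also leave open whether 2-(methylamino)phenyl would give a step of similar size on a compound carrying the side chain of compound 2.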